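A few compounds are considered here, and "the series" means these few. Any claim that something is new, unique, unknown or untested is made for them only; others in the source may bear on it.

Measured so far in a functional assay on A549 cells (Homo sapiens) for cytotoxicity, read by MTT assay, with a stated time of 48 h; on this read-out higher numbers stand for weaker inhibition and lower numbers for stronger inhibition:
Compound 1, `Cc1cccc(Cn2cc(COc3ccc4c(=O)ccoc4c3)nn2)c1`, gives 20300 nM.
Compound 2, `O=c1ccoc2cc(OCc3cn(Cc4ccc(Cl)cc4)nn3)ccc12`, gives only a limit of the assay, > 100000 nM.
Compound 3, `O=c1ccoc2cc(OCc3cn(Cc4cccc(Br)c4)nn3)ccc12`, likewise gives only a limit, > 100000 nM.

Compound 2 thus stands at a limit rather than at a measured number, (the limit of > 100000 nM in this assay, at which 2 of the 3 values shown sit).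

Compound 4, `Cc1ccccc1Cn1cc(COc2ccc3c(=O)ccoc3c2)nn1`, has not yet been measured. It differs from compound 2 by 2-methylphenyl in place of 4-chlorophenyl on a saturated chain carbon bound to an aromatic nitrogen. Going by the values given here, two measured steps bear on this change. Read in the opposite direction, exchanging a methylphenyl for a chlorophenyl gave an at least 4.9-fold higher number from compound 1 to compound 2 (0.69 log units; beyond the scatter), and exchanging methyl for bromo gave an at least 4.9-fold higher number from compound 1 to compound 3 (0.69 log units; beyond the scatter). The remaining step, a step that the two limits leave unreadable from compound 2 to compound 3, cannot be read. In both readable steps the compound carrying a methyl group, compound 1 with its 20300 nM, gave a measured number. The halogen-bearing compound 2 and compound 3 each reached only a limit of the assay. Compound 4 again carries a methyl group, so for compound 4 the expected step is an at least 3.3-fold lower number from compound 2 to compound 4 (0.52 log units; beyond the scatter), a lower number. Compound 4 is estimated at 30000 nM, with a range from 8000 nM to 120000 nM.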

Compound 4, half-maximal inhibitory concentration: > 100000 nM
Compound 4 ended at the assay's limit; the forecaster's own chance of this, stated with the estimate: 40%; middle value at least 3.3-fold (0.52 log units) from the limit.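

Exchanging 3-methylphenyl for 2-methylphenyl on the saturated chain carbon bound to an aromatic nitrogen gave an at least 4.9-fold higher number from compound 1 to compound 4 (0.69 log units; beyond the scatter), so in this assay the presence of a methyl group alone does not secure a measured number. Compound 4 gives only a limit of the assay, and compound 1 is now the only compound shown with a measured value: the limit of > 100000 nM in this assay, at which 3 of the 4 values shown sit. The steps from compound 2 and from compound 3 to compound 4 cannot be read, as both ends of each are limits.

On these data alone, how compound 2, compound 3 and compound 4 truly compare therefore remains open. Also open, as far as these compounds go, is whether a methoxy group or an amine on this benzyl ring would bring a value back within the range of the assay.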